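From Bromo to Nitro in a Growth Inhibition Pair

A few compounds are considered here, and "the series" means these few. Any claim that something is new, unique, unknown or untested is made for them only; others in the source may bear on it.

Compound 1 `N#CCC(=O)N/N=C(/CBr)c1ccc(Br)cc1` gives 12800 nM in a functional assay on SF-268 cells (Homo sapiens) for inhibition, read by sulforhodamine B assay, with a stated time of 48 h (a lower number here means a stronger inhibitor of growth, a higher number a weaker inhibitor of growth), and compound 2 `N#CCC1=NN=C(c2ccc(Br)cc2)C(CC(=O)c2ccc(Br)cc2)O1` gives 16900 nM there, two numbers within the usual scatter of each other. Compound 3 `N#CCC(=O)N/N=C(/CBr)c1ccc([N+](=O)[O-])cc1` differs from compound 1 by nitro in place of bromo on an aromatic carbon, para to a large group (nitro in place of bromo on an aromatic carbon). Among the measured compounds shown here, no measured pair shows such a change, so in this assay no step beyond the scatter is expected, in either direction. The expected 1.2-fold lower number from compound 1 to compound 3 (0.07 log units; within the scatter) would stay within the scatter. Compound 3 is estimated at 11000 nM with an expected range from 4000 nM to 30000 nM for its measurement.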

Compound 3, concentration for 50% growth inhibition: 14000 nM
Compound 3: middle estimate off by 1.3-fold (0.10 log units), on the low side, and the stated range covers the measured number.
By their numbers in this assay, from the lowest: compounds 1, 3 and 2 (each within the scatter of the next).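

At the aromatic carbon para to a large group, nitro in place of bromo gives a 1.1-fold higher number from compound 1 to compound 3 (0.04 log units; within the scatter) in this assay. Among the compounds shown here, this is the first measured step at this position, and it shows that exchanging bromo for nitro, with its 3 heavy atoms and 2 hydrogen-bond acceptors, produces no step beyond the scatter. No supporting measurement bears on why this is so. Only bromo and nitro are shown at this carbon, so the reading with an amine or a carboxylic acid there remains open. Changes elsewhere on the core of compound 1 also remain open.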